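Working notes: acetyl to cyclopropylcarbonyl

A few compounds are considered here, and "the series" means these few. Any claim that something is new, unique, unknown or untested is made for them only; others in the source may bear on it.

- compound 1 `CC(C)(C)OC(=O)N1C[C@@H](n2cc(-c3ccc4c(N)n[nH]c4c3)nn2)C[C@H]1C(=O)Nc1ccc(Br)cc1`: 3710 nM
- compound 2 `Nc1n[nH]c2cc(-c3cn([C@@H]4CN[C@H](C(=O)Nc5ccc(Cl)c(C(F)(F)F)c5)C4)nn3)ccc12`: 8320 nM
- compound 3 `CC(=O)Nc1n[nH]c2cc(-c3cn([C@@H]4CN[C@H](C(=O)Nc5ccc(Cl)c(C(F)(F)F)c5)C4)nn3)ccc12`: 15500 nM

All three values come from a functional assay on K562 cells (Homo sapiens) for inhibition, read by MTT assay, with a stated time of 48 h; a lower number here means a stronger inhibitor, a higher number a weaker inhibitor. In this assay compound 3 gives 15500 nM, the highest number of the three only against compound 1, where the gap lies beyond the scatter. Compound 3 and compound 2 lie within the scatter of each other.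

The next compound is compound 4 `O=C(Nc1n[nH]c2cc(-c3cn([C@@H]4CN[C@H](C(=O)Nc5ccc(Cl)c(C(F)(F)F)c5)C4)nn3)ccc12)C1CC1`, with cyclopropyl in place of methyl on a carbonyl carbon.

Within the data shown here, one measured step bears on this change: a 1.9-fold higher number from compound 2 to compound 3 (0.27 log units; within the scatter), with acetyl in place of hydrogen on a nitrogen on an aromatic ring. Among the measured compounds shown here, that step stayed within the scatter, and no measured step exchanges one acyl group for another. On this thin evidence, no shift beyond the scatter is expected in this assay, and no direction is favoured. The expected step is a 1.0-fold lower number from compound 3 to compound 4 (0.01 log units; within the scatter). The estimated value for compound 4 is 15000 nM, with an expected range from 7000 nM to 32000 nM.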

Compound 4, half-maximal inhibitory concentration: 5200 nM
Compound 4: middle estimate off by 2.9-fold (0.46 log units), on the high side, and the stated range ends above it.
By their numbers in this assay, from the lowest: compounds 1, 4, 2 and 3 (each within the scatter of the next, the first and the last beyond it).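

In this assay, among these compounds, the exchange of acetyl for cyclopropylcarbonyl gives a 3.0-fold lower number from compound 3 to compound 4 (0.47 log units; beyond the scatter) and is the only step in this short series that lies beyond the scatter, so the group on this carbonyl carbon does register in the read-out. Set against the compound with hydrogen on that nitrogen, the picture is flat: a 1.6-fold lower number from compound 2 to compound 4 (0.20 log units; within the scatter) stays inside the scatter, as the acetyl step does, so the two acyl groups separate from each other while neither separates from hydrogen. Nothing given here accounts for the step between the two acyl groups. The compounds shown leave open whether the step follows the ring or simply the added carbons, which a propanoyl or cyclobutylcarbonyl group on the same nitrogen would help to tell. A single pair also leaves open whether the step holds on another anilide.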